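Swapping methoxy for 2,6-dimethylphenoxy on compound 2

This account rests on a few compounds, and the source may have more. Where it says the series, first, only, none or still open, it means among the compounds named here.

Measured in an ADME assay on HEK293 cells (Homo sapiens) for cytotoxicity, read by luminescence, with a stated time of 72 h; a lower number here means that less compound is needed, a higher number that more compound is needed for the effect:
- compound 1 `CCOC(=O)c1c(-c2cccc(OC)c2)[nH]c2cc(OC)ccc2c1=O`: > 22000 nM (a limit, not a number)
- compound 2 `CCOC(=O)c1c(-c2cccc(OC)c2)[nH]c2cc(OC)c(F)cc2c1=O`: > 22000 nM (a limit, not a number)

Compound 2 therefore has no exact position on the scale, only its limit. It shares that standing with compound 1: the limit of > 22000 nM in this assay, at which 2 of the 2 values shown sit.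

Compound 3 `CCOC(=O)c1c(-c2cccc(Oc3c(C)cccc3C)c2)[nH]c2cc(OC)c(F)cc2c1=O` carries 2,6-dimethylphenyl in place of methyl on an oxygen on an aromatic ring. Among the measured compounds shown here, the only measured step, a step that the two limits leave unreadable from compound 1 to compound 2, is a different change and gives no size to carry over. The size of the next step must therefore be judged with little support. The expected step is modest and towards a lower number, an at least 1.2-fold lower number from compound 2 to compound 3 (0.08 log units; that floor lies within the scatter), though another limit is also expected to be quite possible. For compound 3 the estimate is 18000 nM, with an expected range of 6000 nM to 30000 nM.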

Compound 3, half-maximal effective concentration: > 22000 nM
Compound 3 gave a limit, no number; the forecaster's own chance of this, stated with the estimate: 60%; middle value at least 1.2-fold (0.08 log units) from the limit.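

Compound 3, like compound 2, gives a limit and not a number, so the step between them cannot be read: the limit of > 22000 nM in this assay, at which 3 of the 3 values shown sit. Still open is how much of any of these compounds is needed for the effect, and whether swapping methoxy for 2,6-dimethylphenoxy changes that amount at all.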